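A few compounds are considered here, and "the series" means these few. Any claim that something is new, unique, unknown or untested is made for them only; others in the source may bear on it.

Measured in a physicochemical assay for solubility, read by HPLC; a higher number here means a more soluble compound, a lower number a less soluble compound:
- compound 1 `O=C(c1ccc(Cl)cc1)N1CCN(c2nc(=O)c3cc(C(F)(F)F)cc([N+](=O)[O-])c3s2)CC1`: 5.19 ug/mL
- compound 2 `O=c1nc(N2CCN(CC3CCCCC3)CC2)sc2c([N+](=O)[O-])cc(C(F)(F)F)cc12`: 9.07 ug/mL
- compound 3 `CC1COC2(CCN(c3nc(=O)c4cc(C(F)(F)F)cc([N+](=O)[O-])c4s3)CC2)O1`: 0.94 ug/mL

Compound 2 lies within the scatter of compound 1, while compound 3 gives a lower number than compound 2, beyond the scatter. Compound 4 `O=C(C1CCCCC1)N1CCN(c2nc(=O)c3cc(C(F)(F)F)cc([N+](=O)[O-])c3s2)CC1` puts cyclohexylcarbonyl in place of cyclohexylmethyl on an amine nitrogen in a ring. For the measured compounds named here, one measured step bears on this, a 1.7-fold higher number from compound 1 to compound 2 (0.24 log units; within the scatter), where cyclohexylmethyl replaced (4-chlorophenyl)carbonyl at that nitrogen. The new change runs the opposite way, from cyclohexylmethyl back to a carbonyl group, so a small fall within the scatter is expected in this assay. The expected step is a 1.6-fold lower number from compound 2 to compound 4 (0.22 log units; within the scatter). In this assay the estimate for compound 4 is 5.5 ug/mL, with an expected range from 2 ug/mL to 14 ug/mL.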

Compound 4, solubility: 3.24 ug/mL
Compound 4: middle estimate off by 1.7-fold (0.23 log units), on the high side; the range from low to high includes it.
By their numbers in this assay, from the lowest: compound 3; then compounds 4, 1 and 2 (each within the scatter of the next, the first and the last beyond it).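

In this assay, a carbonyl on this ring nitrogen can now be told apart from a plain cyclohexylmethyl: cyclohexylcarbonyl in its place gives a 2.8-fold lower number from compound 2 to compound 4 (0.45 log units; beyond the scatter), whereas the earlier step at this nitrogen stayed within the scatter. On the carbonyl carbon, cyclohexyl in place of 4-chlorophenyl gives a 1.6-fold lower number from compound 1 to compound 4 (0.20 log units; within the scatter), so the identity of that ring makes no readable difference here. Nothing measured here explains these results.

Still open, as far as these compounds go, is whether a simple acetyl group or a longer chain ending in an amine on this nitrogen would fit the same picture.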